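Trifluoromethyl in place of fluoro: one step estimated

The source may report more compounds than this note shows. Statements on the series, on what has been measured and on what is new or still open speak of the compounds shown alone.

compound 1 `CC(=O)Nc1ccc2oc(-c3ccc(C(F)(F)F)cc3)cc(=O)c2c1` gives 10000 nM
compound 2 `CC(=O)Nc1ccc2oc(-c3ccc(F)cc3)c(O)c(=O)c2c1` gives 26000 nM

In an ADME assay on THP-1 cells (Homo sapiens) for cytotoxicity, read by flow cytometry and propidium iodide staining, with a stated time of 72 h (on this read-out lower numbers stand for stronger inhibition and higher numbers for weaker inhibition), compound 2 has the higher of the two numbers (26000 nM), and its gap to compound 1 (10000 nM) lies beyond the scatter. Compound 3 `CC(=O)Nc1ccc2oc(-c3ccc(C(F)(F)F)cc3)c(O)c(=O)c2c1` differs from compound 2 in one place (trifluoromethyl in place of fluoro on an aromatic carbon): trifluoromethyl in place of fluoro on an aromatic carbon. Among the compounds with values here, no measured pair shows this change alone. Compound 1 also carries trifluoromethyl and gives the lower number (10000 nM), which points toward a lower value for compound 3. The expected step (a 1.7-fold lower number from compound 2 to compound 3 (0.24 log units; within the scatter)) is small, about the size of the scatter. The estimated value for compound 3 is 15000 nM (expected range 6000 nM to 35000 nM).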

Compound 3, half-maximal inhibitory concentration: > 50000 nM
Compound 3: a limit, no number; the forecaster's own chance of this, stated with the estimate: 15%; middle value at least 3.3-fold (0.52 log units) from the limit.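

In this assay compound 3 gives > 50000 nM, a limit of the assay and not a number. Trifluoromethyl in place of fluoro gives an at least 1.9-fold higher number from compound 2 to compound 3 (0.28 log units; that floor lies within the scatter), so this change has only a floor, and that floor does not clear the scatter. With trifluoromethyl held fixed, hydroxy in place of hydrogen gives an at least 5.0-fold higher number from compound 1 to compound 3 (0.69 log units; beyond the scatter), a clear shift toward higher numbers. Going by these compounds, the true size of the trifluoromethyl step stays open, since compound 3 has no exact number. On these data alone, whether an amine at this position would also give a higher number also remains open.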